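This account rests on a few compounds, and the source may have more. Where it says the series, first, only, none or still open, it means among the compounds named here.

Measured compounds:
Compound 1 `COc1ccc(-n2ncc3c(NC(C4CC4)C4CC4)nc(C)nc32)c(C)c1`: in a functional assay on CHO cells for antagonist activity at corticotropin-releasing factor receptor 1 (Homo sapiens), read by cAMP accumulation (a lower number here means a stronger inhibitor, a higher number a weaker inhibitor), compound 1 gives 32 nM.
Compound 2 `COc1ccc(-n2c(C)nc3c(NC(C4CC4)C4CC4)nc(C)nc32)cc1`: in this assay compound 2 gives 19 nM.
Compound 3 `COc1ccc(-n2c(C)nc3c(NC(C4CC4)C4CC4)nc(C)nc32)c(C)c1`: in this assay compound 3 gives 14 nM.

All three values lie within the usual scatter of one another, so compound 2 is neither set apart from compound 1 nor from compound 3. Among the measured compounds shown here, the one single-change step seen so far, a 1.4-fold lower number from compound 2 to compound 3 (0.13 log units; within the scatter), is a methyl in place of hydrogen on an aromatic carbon and stays within the scatter. Compound 4 `COCc1nc2c(NC(C3CC3)C3CC3)nc(C)nc2n1-c1ccc(OC)cc1` differs from compound 2 by methoxy in place of hydrogen on a saturated chain carbon bound to an aromatic carbon. For the measured compounds named here, no measured step touches this saturated chain carbon, so nothing among the three compounds speaks for a large move in either direction. The step from compound 2 to compound 4 is therefore expected to be a 1.3-fold higher number from compound 2 to compound 4 (0.12 log units; within the scatter), within the scatter. For compound 4 the estimate in this assay is 25 nM, with a range from 8 nM to 80 nM.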

Compound 4, inhibition constant: 157 nM
Estimate against measurement, compound 4: 6.3-fold (0.80 log units) below, outside the stated range (above it).
By their numbers in this assay, from the lowest: compounds 3, 2 and 1 (each within the scatter of the next, the first and the last beyond it); then compound 4.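

Methoxy in place of hydrogen on a saturated chain carbon bound to an aromatic carbon gives, in this assay, an 8.3-fold higher number from compound 2 to compound 4 (0.92 log units; beyond the scatter) and is the first single change here to pass beyond the scatter. The methyl swap on an aromatic carbon, a 1.4-fold lower number from compound 2 to compound 3 (0.13 log units; within the scatter), gave no such sign, so this chain carbon is the first place shown where one change moves the number clearly. No evidence is available to explain this step.

Going by these compounds, how an ethyl or a hydroxymethyl group would read on this carbon remains open. So does whether the step would hold in compound 3.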